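A few compounds are considered here, and "the series" means these few. Any claim that something is new, unique, unknown or untested is made for them only; others in the source may bear on it.

In an ADME assay on the whole organism (Mus musculus, strain BALB/c) for metabolic stability, read by LC-MS, with a stated time of 600 min, at a dose of 20 mg/kg by the intravenous route (a lower number here means that the compound disappears faster, a higher number that the compound lasts longer), compound 2 (`CC(C)NC[C@@H]1C[C@H](c2ccc3c(N)ncnn23)[C@@H](O)[C@H]1O`) gives 1.11 h and compound 1 (`CN(CCCNC(=O)Nc1ccc(C(C)(C)C)cc1)C[C@H]1C[C@@H](c2ccc3c(N)ncnn23)[C@H](O)[C@@H]1O`) gives 1.97 h, two values within the scatter of each other. The next member is compound 3 (`CC(C)NC[C@H]1C[C@@H](c2ccc3c(N)ncnn23)[C@H](O)[C@@H]1O`), related to compound 2 as follows: the two compounds have the same atoms and bonds and differ only in configuration as drawn: 4 of 4 stereo elements differ (all stereocentres are inverted: mirror images); a stereocentre at a saturated ring carbon is drawn S in compound 2 and R in compound 3; a stereocentre at a saturated ring carbon is drawn R in compound 2 and S in compound 3; a stereocentre at a saturated ring carbon is drawn R in compound 2 and S in compound 3; a stereocentre at a saturated ring carbon is drawn S in compound 2 and R in compound 3. Going by the values given here, no measured pair shows what such an inversion does in this assay, so no step beyond the scatter is expected, in either direction. The expected 1.1-fold higher number from compound 2 to compound 3 (0.03 log units; within the scatter) is small. For compound 3 the estimated half-life is 1.2 h, with an expected range from 0.6 h to 2.4 h.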

Compound 3, half-life: 1.92 h
The estimate for compound 3 lay 1.6-fold (0.20 log units) below the measured number; the range from low to high includes it.
By their numbers in this assay, from the lowest: compounds 2, 3 and 1 (each within the scatter of the next).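

Inverting all four stereocentres gives the first single-place step in the series in this assay (a 1.7-fold higher number from compound 2 to compound 3 (0.24 log units; within the scatter)). This step lies within the scatter, so the mirror-image pair shows no separation in half-life that can be read from these two values. The comparison rests on configuration alone: the fact that compounds 2 and 3 differ only in the configuration as drawn

Still open, on these data alone, is whether inverting only one stereocentre, rather than all four, would give a step beyond the scatter. Also open, as far as these compounds go, is whether a carboxylic acid in place of the amine would do so.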